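A Heteroaryl Swap on the Ring Amide of Compound 2

The compounds below may be only part of what the source reports. "The series", "measured", "known", "first", "only" and "open" are said of these compounds alone.

Compound 1, `CCCCNc1nc(N)nc2c1CN(Cc1ccncc1)CC2`: 0.29 uM
Compound 2, `CCCCNc1nc(N)nc2c1CN(C(=O)c1csc(N)n1)CC2`: 6.9 uM

Both were measured in an assay on HEK293 cells for agonist activity at Toll-like receptor 8 (Homo sapiens), read by a luciferase reporter, with a stated time of 6 h; a lower number here means that less compound is needed, a higher number that more compound is needed for the effect. Going by the values given here, compound 2 stands highest of the two numbers; its only neighbour is compound 1, and the step of a 24-fold higher number from compound 1 to compound 2 (1.38 log units; beyond the scatter) lies beyond the scatter. Compound 3, `CCCCNc1nc(N)nc2c1CN(C(=O)c1cc(C)on1)CC2`, has not yet been measured. It differs from compound 2 by 5-methyl-1,2-oxazol-3-yl in place of 2-amino-1,3-thiazol-4-yl on a carbonyl carbon. Among the compounds with values here, the one measured step concerns the group on the amine nitrogen in the ring, not the aromatic ring on the carbonyl carbon, so it does not bear directly on this change; it shows only that compound 2 sits at a higher number than compound 1. Within the data shown here, with no step to go by, no change beyond the scatter is expected, and the expected step of a 1.0-fold higher number from compound 2 to compound 3 (0.01 log units; within the scatter) is accordingly small. Compound 3 is expected to give about 7 uM, with a range from 2 uM to 25 uM.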

Compound 3, minimum effective concentration: 0.4 uM
Compound 3: the middle estimate sits 18-fold (1.24 log units) above what was measured; measured number below the stated range.
By their numbers in this assay, from the lowest: compounds 1 and 3 (each within the scatter of the next); then compound 2.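

In this assay, the aromatic ring on the carbonyl carbon proves to be a sensitive point, since 5-methyl-1,2-oxazol-3-yl in place of 2-amino-1,3-thiazol-4-yl gives a 17-fold lower number from compound 2 to compound 3 (1.24 log units; beyond the scatter). The carbonyl link alone therefore does not fix the high number of compound 2: (5-methyl-1,2-oxazol-3-yl)carbonyl in place of (pyridin-4-yl)methyl on the amine nitrogen in the ring gives a 1.4-fold higher number from compound 1 to compound 3 (0.14 log units; within the scatter). No measurement available here accounts for the difference between the two rings.

The two rings differ at once in their hetero atoms and in carrying an amine or a methyl, and the compounds shown do not separate these changes. A 1,3-thiazol-4-yl ring bearing a methyl or a 1,2-oxazol-3-yl ring bearing an amine would separate them, and an ethyl in place of the methyl would test the space around that substituent.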